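The source may report more compounds than this note shows. Statements on the series, on what has been measured and on what is new or still open speak of the compounds shown alone.

Measured compounds:
compound 1 `CNCCN(C)c1nnnn1Cc1ccc(C(F)(F)F)cc1` — 2%
compound 2 `CNCCN(C)c1nnnn1Cc1ccc(OC(F)(F)F)cc1` — 5%
compound 3 `CN(CCN)Cc1ccc(-c2ccc(C(F)(F)F)cc2)o1` — 37%

In an assay on cells for inhibition of protein arginine N-methyltransferase 1 (Homo sapiens), read by scintillation counting, with stated times of 15 min and 60 min, tested at 9 uM (a lower number here means less inhibition, a higher number more inhibition at the concentration tested (going by the name of the read-out)), compound 1 gives 2% and compound 2 gives 5%. The two share a core and differ only by trifluoromethoxy in place of trifluoromethyl on an aromatic carbon; the step is a number 3 percentage points higher from compound 1 to compound 2 (within the scatter). Compound 3 rests on a different core, and the difference between its core and that of compound 1 is not broken down here. In this assay compound 3 gives 37%, which sets it apart from both compound 1 and compound 2 beyond the scatter.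

Compound 4 `CN(CCN)Cc1ccc(-c2ccc(OC(F)(F)F)cc2)o1` is not yet measured. It differs from compound 3 by trifluoromethoxy in place of trifluoromethyl on an aromatic carbon, the same change that leads from compound 1 to compound 2. Because that earlier step, a number 3 percentage points higher from compound 1 to compound 2 (within the scatter), stayed within the scatter, compound 4 is expected to land close to compound 3, with an estimated step of a number 3 percentage points higher from compound 3 to compound 4 (within the scatter). Within the data shown here, only one prior instance of the change is available, and on a different core, so the range is kept wide. Compound 4 is estimated at 40% in this assay, between 27% and 53%.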

Compound 4, a percentage reported as inhibition, at one concentration (the size of the read-out at that concentration, not a potency): 25%
Beside the measured number, compound 4's estimate is 15 percentage points above it, and the stated range ends above it.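

In this assay, trifluoromethoxy in place of trifluoromethyl on an aromatic carbon gives a number 12 percentage points lower from compound 3 to compound 4 (beyond the scatter), and the two cores do not share one step for this change: the same change on two cores in this assay, a number 3 percentage points higher (within the scatter) from compound 1 to compound 2 and a number 12 percentage points lower (beyond the scatter) from compound 3 to compound 4, 15 percentage points apart, beyond the scatter of two such steps

A step read on one of these cores is therefore no reliable guide to the same change on the other, and trifluoromethyl is the better of the two groups on the core of compound 3 only. The result rests on a single pair per core, read at one concentration in this assay, so it gives no reason for the difference and no rule for any further core.

Still open, as far as these compounds go, is how a nitrile, a chlorine or a methyl group would fare on the same aromatic carbon of the core of compound 3, where the two fluorinated groups differ. Also open, from the compounds shown here alone, is whether a longer chain carrying the terminal amine would change the size of this step on either core.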